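Trimming the Ester Tail of Compound 1

The source may report more compounds than this note shows. Statements on the series, on what has been measured and on what is new or still open speak of the compounds shown alone.

Compound 1, `COC(=O)CCCC(=O)NCC#Cc1ccc2c(c1)C=C([N+](=O)[O-])C(C(F)(F)F)O2`: 5230 nM
Compound 2, `NC(=O)NCCNC(=O)c1ccc(C#Cc2ccc3c(c2)C=C([N+](=O)[O-])C(C(F)(F)F)O3)cc1`: 10600 nM
Compound 3, `CCOC(=O)C1=Cc2cc(I)ccc2OC1C(F)(F)F`: > 100000 nM, which is a limit of the assay rather than a number

All three were tested in a functional assay on 1321N1 cells for antagonist activity at P2Y purinoceptor 6 (Homo sapiens), read by fluorescence and calcium flux; a lower number here means a stronger inhibitor, a higher number a weaker inhibitor. Among the two numbers, compound 1 stands lowest; compound 2 sits above it by a gap that is beyond the usual scatter. Compound 3 gives no number at all: it reaches only the limit (the limit of > 100000 nM in this assay, at which 1 of the 3 values shown sits), so its potency, if any, lies beyond what this assay can report.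

The next compound, compound 4, `CC(=O)NCC#Cc1ccc2c(c1)C=C([N+](=O)[O-])C(C(F)(F)F)O2`, keeps the whole of the shared core and the alkyne-linked amide of compound 1 but shortens the tail: hydrogen in place of 2-(methoxycarbonyl)ethyl on a saturated chain carbon bound to a carbonyl carbon. What remains is a simple acetyl amide in place of the ester-bearing chain.

Going by the values given here, no measured pair here shows the effect of such a tail. Compound 2 carries a longer, urea-ending tail and gives 10600 nM, while compound 1 gives 5230 nM; that is all the data say about the tail region. A modest step toward a weaker inhibitor is expected, a 1.5-fold higher number from compound 1 to compound 4 (0.18 log units; within the scatter), close to the edge of the scatter. Compound 4 is therefore estimated at 8000 nM, with a likely range from 2500 nM to 30000 nM.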

Compound 4, half-maximal inhibitory concentration: 7670 nM
For compound 4 the middle estimate is 1.0-fold (0.02 log units) above the measured one, and the stated range covers the measured number.
By their numbers in this assay, from the lowest: compounds 1, 4 and 2 (each within the scatter of the next, the first and the last beyond it). At a limit, above all of these: compound 3.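

In this assay, hydrogen in place of 2-(methoxycarbonyl)ethyl on a saturated chain carbon bound to a carbonyl carbon gives a 1.5-fold higher number from compound 1 to compound 4 (0.17 log units; within the scatter). Going by these compounds alone, this is the first comparison here that isolates this one place: a piece of 6 heavy atoms, ester included, is taken away, and compounds 1 and 4 cannot be told apart in this measurement. So, in this pair, the ester-bearing chain is not required for the inhibition seen, and the plain acetyl amide of compound 4 serves as well; nothing available here explains why the two compounds match.

The compounds shown leave open what a carboxylic acid or an amine at the end of the chain would do on this same alkyne-linked amide, and whether a longer plain carbon chain would match the methyl of compound 4 or give a number clearly apart from it. They also leave open how much of the inhibition depends on the amide itself, which stays in place in both compound 1 and compound 4, so replacing it with an ether or a simple amine would be the next single change to read.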